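Acyl variation on the hydrazone-thiazole series

A few compounds are considered here, and "the series" means these few. Any claim that something is new, unique, unknown or untested is made for them only; others in the source may bear on it.

Measured so far:
Compound 1 `CN(C(=O)NC(=O)c1cccc(C(F)(F)F)c1)c1nc(C(F)(F)F)c(C(=O)N/N=C/c2ccc(C(F)(F)F)cc2)s1` gives 7.71 ug/mL in a functional assay on HepG2 cells (Homo sapiens) for inhibition, read by MTT assay, with a stated time of 72 h; on this read-out higher numbers stand for weaker inhibition and lower numbers for stronger inhibition.
Compound 2 `CN(C(=O)NC(=O)c1cccc(C(F)(F)F)c1)c1nc(C(F)(F)F)c(C(=O)N/N=C/c2ccccc2C(F)(F)F)s1` gives 10.4 ug/mL in this assay.
Compound 3 `CN(C(=O)NC(=O)c1ccccc1F)c1nc(C(F)(F)F)c(C(=O)N/N=C/c2cc(C(F)(F)F)cc(C(F)(F)F)c2)s1` gives 4.47 ug/mL in this assay.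

Compound 2 has the highest number of the three; compound 1 lies within the scatter of it, while compound 3 stands beyond the scatter, with the lower number. For the measured compounds named here, the only single-point step measured so far, a 1.3-fold higher number from compound 1 to compound 2 (0.13 log units; within the scatter), concerns the aryl group on the hydrazone side and is within the scatter.

Compound 4 `CN(C(=O)NC(=O)c1ccccc1F)c1nc(C(F)(F)F)c(C(=O)N/N=C/c2ccccc2C(F)(F)F)s1` changes the other end of compound 2: 2-fluorophenyl in place of 3-(trifluoromethyl)phenyl on a carbonyl carbon. Going by the values given here, no measured pair isolates this acyl exchange. Compound 3 carries the same 2-fluorophenyl carbonyl and shows the lowest number, but it also differs from compound 2 at the hydrazone aryl, so its value cannot be read as a step for the acyl change alone. With nothing bearing directly on this exchange, the expectation is a number close to that of compound 2, with a slight lean toward a lower value and a wide range.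

Compound 4 is estimated at 8 ug/mL, between 3.5 ug/mL and 18 ug/mL, which would mean a step of a 1.3-fold lower number from compound 2 to compound 4 (0.11 log units; within the scatter).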

Compound 4, half-maximal inhibitory concentration: 5.39 ug/mL
Estimate against measurement, compound 4: 1.5-fold (0.17 log units) above; low and high end bracket the measured number.
By their numbers in this assay, from the lowest: compounds 3, 4, 1 and 2 (each within the scatter of the next, the first and the last beyond it).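

In this assay, for the compounds shown here, the exchange of 3-(trifluoromethyl)phenyl for 2-fluorophenyl on a carbonyl carbon gives a 1.9-fold lower number from compound 2 to compound 4 (0.29 log units; within the scatter) and is the first reading at this position with the rest of the structure held constant. Even with the trifluoromethyl group replaced by a single fluorine, the step stays within the scatter, so this one pair does not separate the two aryl groups. Nothing on hand explains the size of this step.

Going by these compounds, it remains open whether the same acyl exchange would read alike with the 4-(trifluoromethyl)phenyl group of compound 1 on the carbon with a double bond to nitrogen. Also open, on these data alone, is how this position would respond if an aliphatic amine or a carboxylic acid replaced the aryl group on the carbonyl carbon.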